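This account rests on a few compounds, and the source may have more. Where it says the series, first, only, none or still open, it means among the compounds named here.

Working notes on the series.

The series is read in a functional assay on CHO cells for agonist activity at Free fatty acid receptor 1 (Homo sapiens), read by FLIPR and calcium flux, tested at 100 nM; on this read-out higher numbers stand for a stronger effect at the one concentration tested and lower numbers for a weaker effect. Of the compounds shown here, two have a number so far. Compound 1, `Cc1nc(-c2ccccc2)oc1COc1ccc2c(c1)OCC2CC(=O)O`, gives 7.15%. Compound 2, `Cc1nc(-c2ccccc2Cl)sc1COc1ccc2c(c1)OCC2CC(=O)O`, gives 12.4%. Among the compounds with values here, compound 2 and compound 1 sit within the scatter of each other, so nothing can be said about an order between them; both numbers are small at the single concentration tested, and no step between measured compounds is available to show how a change on this part of the structure moves the read-out.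

The next member is compound 3, `COc1cc(OC)cc(-c2nc(C)c(COc3ccc4c(c3)OCC4CC(=O)O)s2)c1`. Relative to compound 2 the change is 3,5-dimethoxyphenyl in place of 2-chlorophenyl on an aromatic carbon.

With no measured step of this kind in hand, and with both known numbers low and close to each other, the expectation is that the step from compound 2 to compound 3 stays within the scatter, in no clear direction, as a number 0.4 percentage points lower from compound 2 to compound 3 (within the scatter). Compound 3 is therefore estimated at 12% in this assay, with a range from 3% to 30%.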

Compound 3, a percentage reported as activity, at one concentration (the size of the read-out at that concentration, not a potency): 17.5%
Beside the measured number, compound 3's estimate is 5.5 percentage points below it; the measured number falls inside the stated range.
By their numbers in this assay, from the lowest: compounds 1, 2 and 3 (each within the scatter of the next, the first and the last beyond it).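

In this assay, within the data shown here, the exchange at this position, on an aromatic carbon of the five-membered aromatic ring with 1 nitrogen and 1 sulfur, gives the first measured step, a number 5.1 percentage points higher from compound 2 to compound 3 (within the scatter). Replacing 2-chlorophenyl, with 7 heavy atoms and 0 hydrogen-bond acceptors, by 3,5-dimethoxyphenyl, with 10 heavy atoms and 2 hydrogen-bond acceptors, therefore gives no readable order between the two compounds, and this one step shows that the position can carry either aryl group without a difference beyond the scatter. Nothing measured on these compounds accounts for the step or assigns it to either the chlorine or the two methoxy groups.

Going by these compounds, it remains open whether a substituent of another kind at this position, such as an amine or a carboxylic acid on the phenyl ring or a longer chain in place of the ring, would move the read-out beyond the scatter. It also remains open whether a phenyl ring with a single methoxy group would read differently from the 3,5-dimethoxyphenyl group, and a single concentration cannot show how any of these compounds would compare in potency.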